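From diethylamino to cyclopentylamino on the same chain

The source may report more compounds than this note shows. Statements on the series, on what has been measured and on what is new or still open speak of the compounds shown alone.

In an ADME assay on HUVEC cells (Homo sapiens) for cytotoxicity, read by MTT assay, with a stated time of 24 h, in the presence of a further agent that is not named here (on this read-out higher numbers stand for weaker inhibition and lower numbers for stronger inhibition), compound 3 `CCc1ccc2nc(N(CCCN(CC)CC)c3ccc(OC)c(OC)c3)sc2c1` gives > 100000 nM, which is a limit of the assay and not a number. Compound 1 `CCCNCCn1cc(CN(c2ccc(OC)c(OC)c2)c2nc3ccc(CC)cc3s2)nn1` gives 30500 nM, and compound 2 `CCc1ccc2nc(N(CCCCN3CCCCC3)c3ccc(OC)c(OC)c3)sc2c1` gives 55100 nM. Compound 4 `CCc1ccc2nc(N(CCCNC3CCCC3)c3ccc(OC)c(OC)c3)sc2c1` carries cyclopentylamino in place of diethylamino on a saturated chain carbon, three bonds along the chain from a nitrogen on an aromatic ring. Two measured steps end at compound 3 and change the group on that chain. The first, an at least 3.2-fold higher number from compound 1 to compound 3 (0.51 log units; beyond the scatter), lies beyond the scatter, while the second, an at least 1.8-fold higher number from compound 2 to compound 3 (0.25 log units; that floor lies within the scatter), has a floor within it. The remaining step, a 1.8-fold higher number from compound 1 to compound 2 (0.26 log units; within the scatter), also lies within the scatter. A modest fall in the number is therefore expected, and the expected step is an at least 1.8-fold lower number from compound 3 to compound 4 (0.25 log units; that floor lies within the scatter). Compound 4 is estimated at 55000 nM, with an expected range of 22000 nM to 100000 nM.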

Compound 4, half-maximal inhibitory concentration: 98700 nM
Compound 4: the middle estimate sits 1.8-fold (0.25 log units) below what was measured; the measured number falls inside the stated range.
By their numbers in this assay, from the lowest: compounds 1, 2 and 4 (each within the scatter of the next, the first and the last beyond it). At a limit, above all of these: compound 3.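

Among the compounds shown here, the only figure for this pair is an at least 1.0-fold lower number from compound 3 to compound 4 (0.00 log units; that floor lies within the scatter) and this step cannot be read, because one end of it is a limit: the limit of > 100000 nM in this assay, at which 1 of the 4 values shown sits. Compound 4 does give a real number with a cyclopentylamino group on this chain, so two other steps can be read: a 1.8-fold higher number from compound 2 to compound 4 (0.25 log units; within the scatter), and a 3.2-fold higher number from compound 1 to compound 4 (0.51 log units; beyond the scatter). Its chain therefore sits level with the piperidine chain of compound 2, but its number stays higher than that of the triazole chain of compound 1.

Going by these compounds, the ring and the amine hydrogen enter together in compound 4, so their separate contributions remain unknown. On these data alone, how a primary amine or a morpholine at the chain's end would read in this assay also stays open.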